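A Benzamide in Place of the Imidazolyl Carboxamide

This account rests on a few compounds, and the source may have more. Where it says the series, first, only, none or still open, it means among the compounds named here.

Compound 2 `Cn1ccnc1NC(=O)c1cccc(Nc2ncc(F)c(Nc3ccc(F)cc3)n2)c1` is the starting point, measured in a functional assay on KB cells (Homo sapiens) for antiproliferative activity, read by sulforhodamine B assay, with a stated time of 3 days (on this read-out higher numbers stand for weaker inhibition of growth and lower numbers for stronger inhibition of growth), where compound 2 gives 14600 nM. This is the highest of the two numbers in hand, yet the step of a 1.2-fold higher number from compound 1 to compound 2 (0.07 log units; within the scatter) shows that compound 1 `O=C(NCCO)c1cccc(Nc2ncc(F)c(Nc3ccc(F)cc3)n2)c1` stands within the scatter of it. In this assay compound 1 gives 12400 nM. Compound 3 `O=C(Nc1ccc(C(F)(F)F)cc1)c1cccc(Nc2ncc(F)c(Nc3ccc(F)cc3)n2)c1` gives only a limit of this assay, > 10000 nM. The steps a step that the limit leaves unreadable from compound 1 to compound 3 and a step that the limit leaves unreadable from compound 2 to compound 3 are therefore of unreadable size, both running into (the limit of > 10000 nM in this assay, at which 1 of the 3 values shown sits).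

Compound 4 `O=C(Nc1cccc(Nc2ncc(F)c(Nc3ccc(F)cc3)n2)c1)c1ccccc1` differs from compound 2 by benzamido in place of (1-methyl-1H-imidazol-2-yl)carbamoyl on an aromatic carbon. Among the measured steps, only the one to compound 3 also brings a six-membered aromatic ring of carbon only onto this side of the shared core, and there the number could not be read. The account thus expects compound 4 to sit at or beyond the weaker end of what has been seen, with the estimated step of a 1.4-fold higher number from compound 2 to compound 4 (0.14 log units; within the scatter) pointing toward a higher number. Compound 4 is estimated at 20000 nM, within a range from 6000 nM to 60000 nM.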

Compound 4, concentration for 50% growth inhibition: > 10000 nM
Compound 4: only a limit was reported; the forecaster's own chance of this, stated with the estimate: 45%; the middle value does not contradict the limit.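

In this assay compound 4 gives only a limit, > 10000 nM. The steps to it from compound 1 and compound 2 therefore cannot be read: the limit of > 10000 nM in this assay, at which 2 of the 4 values shown sit.

The compounds shown leave open how compound 3 and compound 4 compare with each other and with compound 1 and compound 2.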